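This account rests on a few compounds, and the source may have more. Where it says the series, first, only, none or still open, it means among the compounds named here.

In an ADME assay on CEMx174 cells (Homo sapiens) for cytotoxicity (on this read-out lower numbers stand for higher toxicity in this test and higher numbers for lower toxicity in this test), three related compounds have been measured. Compound 1 (`CC1=C(C(=O)OCC2CCCCC2)C(c2cccc(O)c2)N(C)C(=O)N1`) gives > 10000 nM as a limit of the assay, not a number. Compound 2 (`CC1=C(C(=O)OCC2CCCCC2)C(c2cccc(O)c2)NC(=S)N1`) gives > 10000 nM as a limit too. Compound 3 (`CCC1=C(C(=O)OCC2CCCCC2)C(c2ccc([N+](=O)[O-])cc2)NC(=O)N1`) gives > 10000 nM as a limit once more. Compound 3 therefore stands at the limit of > 10000 nM in this assay, at which 3 of the 3 values shown sit, and has no exact number. Compound 4 (`CCC1=C(C(=O)OCC2CCCCC2)C(c2ccc(C#N)cc2)NC(=O)N1`) carries cyano in place of nitro on an aromatic carbon para to a large group. Within the data shown here, no measured step is available to guide this swap, so the expected change (a number no higher from compound 3 to compound 4 (the limit leaves the size open)) is none beyond the usual scatter. In this assay compound 4 is expected to read 10000 nM with an estimated range of 5000 nM to 20000 nM and may well return only a limit.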

Compound 4, half-maximal cytotoxic concentration: > 10000 nM
Compound 4: only a limit was reported (the forecaster's own chance of this, stated with the estimate: 85%); the middle value lies on the limit itself.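

Compound 3 and compound 4 both give only a limit in this assay, so no step can be read for cyano in place of nitro. The compounds shown leave open what exact half-maximal cytotoxic concentration any of them has, and whether they differ at all: the limit of > 10000 nM in this assay, at which 4 of the 4 values shown sit.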